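The source may report more compounds than this note shows. Statements on the series, on what has been measured and on what is new or still open speak of the compounds shown alone.

Measured compounds:
compound 1 `CCCC[C@H](Oc1ncc(-c2ccccc2)cn1)c1ccc(C(=O)NCCC(=O)O)cc1` — 8500 nM
compound 2 `CCCCC(Oc1ncc(-c2ccccc2)cn1)c1ccc(C(=O)NCCC(=O)O)cc1` — 4100 nM

The study is read out in a functional assay on cells for antagonist activity at Glucagon receptor (Homo sapiens), read by luminescence and cAMP accumulation, with stated times of 10 min and 30 min; a lower number here means a stronger inhibitor, a higher number a weaker inhibitor. Of the two measured compounds, compound 1 gives the higher number, 8500 nM, and its nearest neighbour is compound 2 with 4100 nM, so compound 1 stands at the weak end of what has been measured.

Compound 3 `CCCC[C@@H](Oc1ncc(-c2ccccc2)cn1)c1ccc(C(=O)NCCC(=O)O)cc1` has not yet been measured. It differs from compound 1 in one respect only: the two compounds have the same atoms and bonds and differ only in configuration as drawn: 1 of 1 stereo elements differ; a stereocentre at a saturated chain carbon is drawn S in compound 1 and R in compound 3. Going by the values given here, the one measured step that bears on this is a 2.1-fold lower number from compound 1 to compound 2 (0.32 log units; beyond the scatter), where the two compounds have the same atoms and bonds and differ only in that compound 2 is drawn without a configuration at that chain carbon (the fact that one of compounds 1 and 2 is drawn with a defined configuration and the other without, at the place where they differ). A compound drawn without configuration is expected to behave as a mixture of both configurations, and since that mixture already gives a lower number than compound 1, the configuration not yet measured, that of compound 3, is expected to give a lower number still. Compound 3 is therefore estimated at 3000 nM, with a range of 1200 nM to 8000 nM, an expected step of a 2.8-fold lower number from compound 1 to compound 3 (0.45 log units; beyond the scatter).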

Compound 3, half-maximal inhibitory concentration: 9300 nM
The estimate for compound 3 lay 3.1-fold (0.49 log units) below the measured number; measured number outside the range, above it.
By their numbers in this assay, from the lowest: compound 2; then compounds 1 and 3 (each within the scatter of the next).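

Drawing the saturated chain carbon R rather than S gives a 1.1-fold higher number from compound 1 to compound 3 (0.04 log units; within the scatter), so in this assay the two drawn configurations at this stereocentre cannot be told apart: the fact that compounds 1 and 3 differ only in the configuration as drawn

Compound 3 also stands apart from the compound drawn without a configuration, with a 2.3-fold higher number from compound 2 to compound 3 (0.36 log units; beyond the scatter): the fact that one of compounds 2 and 3 is drawn with a defined configuration and the other without, at the place where they differ

Compound 2 therefore gives a lower number than both compounds with a drawn configuration, and its steps to each lie beyond the scatter, a result that a simple mixture of compound 1 and compound 3 would not be expected to give, so choosing one configuration at this carbon offers no route to a lower number in this series.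

What lies behind the lower number of compound 2 stays open, since these compounds hold no direct measure of its make-up or purity. Going by these compounds, it is also open whether the configuration at this carbon would count for more with a different group there, such as a longer chain or a cyclohexyl group, or with a tetrazole in place of the carboxylic acid.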